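Benzyl linker replacing the amine in a coumarin amide series

This account rests on a few compounds, and the source may have more. Where it says the series, first, only, none or still open, it means among the compounds named here.

In a functional assay on SK-BR-3 cells (Homo sapiens) for antiproliferative activity (on this read-out lower numbers stand for stronger inhibition and higher numbers for weaker inhibition), compound 1 `COc1ccc(Oc2ccc3cc(NC(=O)c4ccc(OC(C)=O)c(CC=C(C)C)c4)c(=O)oc3c2C)cc1` gives 19500 nM. Compound 2 `CC(=O)Oc1ccc(C(=O)Nc2cc3ccc(Oc4ccc(C(C)(C)C)cc4)c(C)c3oc2=O)cc1CC=C(C)C`, which carries a tert-butyl in place of methoxy on an aromatic carbon, gives 72400 nM, a step of a 3.7-fold higher number from compound 1 to compound 2 (0.57 log units; beyond the scatter). Compound 3 `COc1ccc(Nc2ccc3cc(NC(=O)c4ccc(OC(C)=O)c(CC=C(C)C)c4)c(=O)oc3c2C)cc1` reaches only the limit of this assay, > 100000 nM, so for compound 3 only a floor is known, as the line the limit of > 100000 nM in this assay, at which 1 of the 3 values shown sits, records. The step of an at least 5.1-fold higher number from compound 1 to compound 3 (0.70 log units; beyond the scatter) shows that the (4-methoxyphenyl)amino linkage is the weaker of the two; the step of an at least 1.3-fold higher number from compound 2 to compound 3 (0.14 log units; that floor lies within the scatter) does not resolve beyond the scatter. Compound 4 `COc1ccc(Cc2ccc3cc(NC(=O)c4ccc(OC(C)=O)c(CC=C(C)C)c4)c(=O)oc3c2C)cc1` differs from compound 3 in that (4-methoxybenzyl in place of (4-methoxyphenyl)amino on an aromatic carbon). Going by the values given here, the ether-linked compound 1 and the amine-linked compound 3 bracket what a methylene link might give, and no measured step maps this change directly. Compound 4 is therefore expected to give 40000 nM, within a range from 12000 nM to 130000 nM. That estimate corresponds to an at least 2.5-fold lower number from compound 3 to compound 4 (0.39 log units; beyond the scatter), though a further limit reading remains possible.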

Compound 4, half-maximal inhibitory concentration: 23500 nM
The estimate for compound 4 lay 1.7-fold (0.23 log units) above the measured number, within the range that was stated.
By their numbers in this assay, from the lowest: compounds 1 and 4 (each within the scatter of the next); then compound 2. At a limit, above all of these: compound 3.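

In this assay, 4-methoxybenzyl in place of (4-methoxyphenyl)amino gives an at least 4.2-fold lower number from compound 3 to compound 4 (0.62 log units; beyond the scatter), and this step is only a floor, since compound 3 stands at a limit of the assay: the limit of > 100000 nM in this assay, at which 1 of the 4 values shown sits.

Set against the ether-linked group, the same 4-methoxybenzyl group gives a 1.2-fold higher number from compound 1 to compound 4 (0.08 log units; within the scatter), so at this position the methylene and ether links cannot be told apart, while the amine link stays clearly apart from both. The remaining step, a 3.1-fold lower number from compound 2 to compound 4 (0.49 log units; beyond the scatter), replaces the whole 4-(tert-butyl)phenoxy group, so it does not separate the link from the group at the end of the ring.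

The compounds shown leave open whether a carbonyl or sulfur link would read like the methylene and ether links or like the amine link. They also leave open how a 4-(tert-butyl)benzyl group would compare with compound 2.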